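The source may hold more compounds than are shown below. What is called first, only, known or untested is meant among the compounds shown, and "the series" means these compounds.

Measured so far in a functional assay on HT-29 cells (Homo sapiens) for cytotoxicity, read by MTT assay, with a stated time of 72 h; on this read-out lower numbers stand for stronger inhibition and higher numbers for weaker inhibition:
- Compound 1 `O=C(CN1CCN(c2nnc(Cc3ccncc3)c3ccccc23)CC1)Nc1cccc(Br)c1`: 1350 nM
- Compound 2 `O=C(CN1CCN(c2nnc(Cc3ccccc3)c3ccccc23)CC1)Nc1ccc(F)c(C(F)(F)F)c1`: 4590 nM

Of these two compounds, compound 2 holds the higher number at 4590 nM, which makes it the weaker inhibitor. Compound 1 lies lower at 1350 nM, and this gap is beyond the usual scatter of repeated measurements.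

The next compound, compound 3 `O=C(CN1CCN(c2nnc(Cc3ccncc3)c3ccccc23)CC1)Nc1ccc(F)c(C(F)(F)F)c1`, differs from compound 2 in one place: pyridin-4-yl in place of phenyl on a saturated chain carbon bound to an aromatic carbon. Put simply, pyridin-4-yl stands in place of phenyl on a saturated chain carbon bound to an aromatic carbon, so benzyl becomes (pyridin-4-yl)methyl.

Within the data shown here, no measured pair shows this change alone. Among the measured compounds shown here, the only hint comes from compound 1, which carries pyridin-4-yl and gives 1350 nM, but it also differs from compound 3 elsewhere, so this hint is weak. A small move toward a lower number in this assay is therefore expected, one that may stay within the scatter. The estimated change is a 1.8-fold lower number from compound 2 to compound 3 (0.26 log units; within the scatter). The expected value for compound 3 is 2500 nM, with an estimated range of 1000 nM to 7000 nM.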

Compound 3, half-maximal inhibitory concentration: 1110 nM
Compound 3: middle estimate off by 2.3-fold (0.35 log units), on the high side; the range from low to high includes it.
By their numbers in this assay, from the lowest: compounds 3 and 1 (each within the scatter of the next); then compound 2.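

In this assay the swap of phenyl for pyridin-4-yl on a saturated chain carbon bound to an aromatic carbon can now be read on its own, and it gives a 4.1-fold lower number from compound 2 to compound 3 (0.62 log units; beyond the scatter) with everything else in the molecule held the same. A single ring nitrogen, which adds one hydrogen-bond acceptor to a ring of the same size, is thus enough to move the result by more than the usual scatter at this position. Among these compounds, the other new pair holds pyridin-4-yl fixed and places 4-fluoro-3-(trifluoromethyl)phenyl in place of 3-bromophenyl on an amide-type nitrogen, and it gives a 1.2-fold lower number from compound 1 to compound 3 (0.09 log units; within the scatter) so these two groups cannot be told apart here, while nothing measured so far explains either result.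

On these data alone, whether the same step appears with 3-bromophenyl on the amide-type nitrogen remains open, as does the outcome with pyridin-3-yl or pyridin-2-yl on the same carbon. As far as these compounds go, it is equally open whether a longer chain between the core and the pyridin-4-yl ring, or an amine on the phenyl ring, would give a lower or a higher number.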